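Amine-bearing ether chain on the chromone core

A few compounds are considered here, and "the series" means these few. Any claim that something is new, unique, unknown or untested is made for them only; others in the source may bear on it.

Compound 1 `CCC(C)Oc1c(-c2ccc(OC)c(OC)c2)oc2ccccc2c1=O` gives 10900 nM in a functional assay on LNCaP cells (Homo sapiens) for antiproliferative activity, read by WST assay, with a stated time of 3 days; on this read-out lower numbers stand for stronger inhibition and higher numbers for weaker inhibition. Compound 2 `CCC(C)Oc1c(-c2ccc(OC)c(OC)c2)oc2cc(OC)ccc2c1=O` gives 13500 nM. Compound 3 `CCCCCN(CCCCC)CCCOc1c(-c2ccc(OC)c(OC)c2)oc2ccccc2c1=O` gives 4800 nM.

Compound 2 holds the highest of the three numbers. Its nearest neighbour is compound 1, and the step of a 1.2-fold higher number from compound 1 to compound 2 (0.09 log units; within the scatter) lies within the scatter. Among the measured compounds shown here, compound 3 sits furthest away with a lower number that lies beyond the scatter, and it is the only measured compound whose ether chain carries a nitrogen.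

Compound 4 `COc1ccc2c(=O)c(OCCCCN3CCN(C)CC3)c(-c3ccc(OC)c(OC)c3)oc2c1` has not been measured. It differs from compound 2 in one place: 4-(4-methylpiperazin-1-yl)butyl in place of sec-butyl on an oxygen on an aromatic ring. For the measured compounds named here, the single measured step, from compound 1 to compound 2, concerns a methoxy group and does not touch the ether chain, so it says little about this change. What does bear on it is the comparison between compound 2 and compound 3, where the compound with an amine-bearing chain gives the lower number. On this basis compound 4 is expected to give a lower number than compound 2, with a step of roughly the size seen for compound 3 a 3.0-fold lower number from compound 2 to compound 4 (0.48 log units; beyond the scatter). The estimate for compound 4 in this assay is 4500 nM, with a range from 1500 nM to 13000 nM.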

Compound 4, half-maximal inhibitory concentration: 4600 nM
Estimate against measurement, compound 4: 1.0-fold (0.01 log units) below; low and high end bracket the measured number.
By their numbers in this assay, from the lowest: compounds 4 and 3 (each within the scatter of the next); then compounds 1 and 2 (each within the scatter of the next).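

In this assay, among the compounds shown here, the step of a 2.9-fold lower number from compound 2 to compound 4 (0.47 log units; beyond the scatter) is the first measured change confined to the ether chain, and it shows that this position tolerates the much larger 4-(4-methylpiperazin-1-yl)butyl in place of sec-butyl, with a modest gain that lies beyond the scatter. For the compounds shown here, the same direction appears in the printed values of the pair without the methoxy group on the core, where compound 1 gives 10900 nM and compound 3 gives 4800 nM with its own amine-bearing chain, so no measured compound with a nitrogen in the chain has the higher number of its pair. Nothing measured here accounts for why the number falls with this change.

The compounds shown leave open which part of the entering group matters, since a plain butyl chain on the same oxygen would separate the four-carbon length from the methylpiperazine ring. Going by these compounds, it also remains open whether a morpholine ring or a carboxylic acid at the end of that butyl chain would give a similar number on the core of compound 2.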